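Acetyl at a Second Sugar Hydroxyl of a Diterpene Glycoside

The source may report more compounds than this note shows. Statements on the series, on what has been measured and on what is new or still open speak of the compounds shown alone.

Compound 1 `C=C[C@@](C)(CC[C@H]1C(C)=CC[C@H]2C(C)(C)CCC[C@]12C)O[C@@H]1O[C@H](C)[C@H](O)[C@H](O)[C@H]1O` is the parent of this pair. Among the measured compounds shown here, in a functional assay on SK-OV-3 cells (Homo sapiens) for cytotoxicity, read by sulforhodamine B assay (a lower number here means that less compound is needed, a higher number that more compound is needed for the effect), compound 1 gives 3.6 ug/mL, the lowest of the two numbers measured so far, though its nearest neighbour sits within the usual scatter. That neighbour, compound 2 `C=C[C@@](C)(CC[C@H]1C(C)=CC[C@H]2C(C)(C)CCC[C@]12C)O[C@@H]1O[C@H](C)[C@H](OC(C)=O)[C@H](O)[C@H]1O`, carries an acetyl in place of hydrogen on an oxygen on a saturated carbon; in this assay compound 2 gives 5.8 ug/mL, and the step is a 1.6-fold higher number from compound 1 to compound 2 (0.21 log units; within the scatter), within the scatter.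

Compound 3 `C=C[C@@](C)(CC[C@H]1C(C)=CC[C@H]2C(C)(C)CCC[C@]12C)O[C@@H]1O[C@H](C)[C@H](O)[C@H](OC(C)=O)[C@H]1O` is not yet measured. It differs from compound 1 by acetyl in place of hydrogen on an oxygen on a saturated carbon.

For the measured compounds named here, the only step that bears on this change is a 1.6-fold higher number from compound 1 to compound 2 (0.21 log units; within the scatter), an acetylation of a sugar hydroxyl that left the number essentially unchanged. The same kind of change in compound 3 is therefore expected to give a 1.4-fold higher number from compound 1 to compound 3 (0.14 log units; within the scatter), a step not beyond the scatter. Compound 3 is expected to give 5 ug/mL, within a range of 2.5 ug/mL to 10 ug/mL.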

Compound 3, concentration for half-maximal effect: 3.8 ug/mL
Compound 3: middle estimate off by 1.3-fold (0.12 log units), on the high side; low and high end bracket the measured number.
By their numbers in this assay, from the lowest: compounds 1, 3 and 2 (each within the scatter of the next).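

In this assay, hydroxy to acetoxy at this second sugar oxygen gives a 1.1-fold higher number from compound 1 to compound 3 (0.02 log units; within the scatter), so this hydroxy can carry an acetyl without the number leaving the scatter. Together with compound 2, that makes two sugar oxygens at which acetyl in place of hydrogen leaves the number within the scatter of compound 1, so neither free hydroxy is shown to be needed for this read-out. Nothing measured here explains this outcome.

The compounds shown leave open whether a longer acyl chain or a benzoyl group on this oxygen, or an amine in place of the hydroxy, would also stay within the scatter. They also leave open whether acetyl on both of these oxygens at once would do so.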